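Tetrazole for oxetanyl-pyrazole on a biaryl carboxamide core

A few compounds are considered here, and "the series" means these few. Any claim that something is new, unique, unknown or untested is made for them only; others in the source may bear on it.

Compound 1 `CC(C)Oc1cc(-c2cncc(-c3cnn(C4COC4)c3)c2)ccc1C(N)=O`: 200 nM
Compound 2 `Cc1cc(-c2cccnc2)ccc1C(N)=O`: 22000 nM
Compound 3 `Cc1ncccc1-c1ccc(C(N)=O)cc1`: 170000 nM

In an assay on cells for inhibition of MAP kinase-interacting serine/threonine-protein kinase 1 (Homo sapiens), read by mobility shift assay, with stated times of 10 min and 60 min, in the presence of a further agent that is not named here (a higher number here means a weaker inhibitor, a lower number a stronger inhibitor), compound 1 gives 200 nM, the lowest of the three numbers; compound 2 gives 22000 nM and compound 3 gives 170000 nM, both beyond the scatter from compound 1. Within the data shown here, no step between two measured compounds differs in a single place, so the change to compound 4 `CC(C)Oc1cc(-c2cncc(-c3nn[nH]n3)c2)ccc1C(N)=O` has no direct precedent: 2H-tetrazol-5-yl in place of 1-(oxetan-3-yl)-1H-pyrazol-4-yl on an aromatic carbon. The shared core of compound 1 is kept. Without a comparable pair in this assay, a modest loss is expected, with wide uncertainty. A step of a 4.0-fold higher number from compound 1 to compound 4 (0.60 log units; beyond the scatter) is expected. Compound 4 is estimated at 800 nM, within a range from 150 nM to 5000 nM.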

Compound 4, half-maximal inhibitory concentration: 310 nM
Beside the measured number, compound 4's estimate is 2.6-fold (0.41 log units) above it, within the range that was stated.
By their numbers in this assay, from the lowest: compounds 1 and 4 (each within the scatter of the next); then compound 2; then compound 3.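

In this assay, 2H-tetrazol-5-yl in place of 1-(oxetan-3-yl)-1H-pyrazol-4-yl gives a 1.6-fold higher number from compound 1 to compound 4 (0.19 log units; within the scatter), so the position meta to a large group keeps its reading with the four-membered non-aromatic ring gone and a hydrogen-bond donor present. The earlier compounds shown here could not show this, as none of them formed a single-place pair. No measurement shown here accounts for the two groups reading alike. On these data alone, whether a carboxylic acid or a primary amine on the same aromatic carbon would also stay within the scatter of compound 1 remains open.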